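This account rests on a few compounds, and the source may have more. Where it says the series, first, only, none or still open, it means among the compounds named here.

Series notes. The shared core is seen in compound 1 `Cc1ccnnc1N1CCN(c2ncccn2)CC1`. In a functional assay on BV-2 cells (Mus musculus) for inhibition, read by ELISA, with a stated time of 16 h (on this read-out higher numbers stand for weaker inhibition and lower numbers for stronger inhibition), compound 1 gives only a limit of the assay, > 100000 nM. Compound 2 `Cc1cc(-c2ccncc2)nnc1N1CCN(c2ncccn2)CC1` carries pyridin-4-yl in place of hydrogen on an aromatic carbon, and in this assay compound 2 likewise gives only a limit, > 100000 nM. The step that the two limits leave unreadable from compound 1 to compound 2 therefore cannot be read in size or direction; the limit of > 100000 nM in this assay, at which 2 of the 2 values shown sit, is all the record holds, so compound 2 stands at that limit and nowhere more precise. Compound 3 `Cc1cc(-c2cc3ccccc3s2)nnc1N1CCN(c2ncccn2)CC1` is not yet measured; it differs from compound 2 by 1-benzothiophen-2-yl in place of pyridin-4-yl on an aromatic carbon. For the measured compounds named here, no measured step bears on this change: the only step between measured compounds is unreadable, and no value so far is a number rather than a limit. For compound 3 a result at the same limit is expected in this assay, so the expected step of a number no higher from compound 2 to compound 3 (the limit leaves the size open) is one that would not be readable either. The estimate for compound 3 is 100000 nM, with a range of 20000 nM to 300000 nM.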

Compound 3, half-maximal inhibitory concentration: 24900 nM
Compound 3: the middle estimate sits 4.0-fold (0.60 log units) above what was measured; the range from low to high includes it.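

In this assay, this aromatic carbon of the shared core now yields a first readable change: 1-benzothiophen-2-yl in place of pyridin-4-yl gives an at least 4.0-fold lower number from compound 2 to compound 3 (0.60 log units; beyond the scatter), so the group at this position can move the read-out, which the earlier pair could not show. Set against hydrogen at the same carbon, 1-benzothiophen-2-yl gives an at least 4.0-fold lower number from compound 1 to compound 3 (0.60 log units; beyond the scatter), so the change is seen against both earlier compounds and not against pyridin-4-yl alone. Compound 3 remains the only compound in the series with a number rather than a limit: the limit of > 100000 nM in this assay, at which 2 of the 3 values shown sit.

Going by these compounds, both steps are open-ended, so their true sizes remain unknown, and the order of hydrogen and pyridin-4-yl at this position cannot be read. The compounds shown also leave open whether the result needs both rings of 1-benzothiophen-2-yl or its sulfur, and how a smaller phenyl group or a simple amine at this carbon would read in this assay.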